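The source may hold more compounds than are shown below. What is called first, only, known or untested is meant among the compounds shown, and "the series" means these compounds.

Compound 1 `Cc1nc(S(C)(=O)=O)ccc1Oc1ncnc(OC2CCN(C(=O)OC3(C(F)(F)F)COC3)CC2)c1F`: 342 nM
Compound 2 `Cc1nc(S(C)(=O)=O)ccc1Oc1ncnc(OC2CCN(C(=O)SC(C)(C)C)CC2)c1F`: 30.7 nM
Compound 3 `CCC(F)(F)C(=O)N1CCC(Oc2ncnc(Oc3ccc(S(C)(=O)=O)nc3C)c2F)CC1`: 69.2 nM

In a functional assay on isolated protein for inhibition of Glucose-dependent insulinotropic receptor (Rattus norvegicus), read by HTRF and cAMP accumulation (a lower number here means that less compound is needed, a higher number that more compound is needed for the effect), compound 3 gives 69.2 nM, the second highest of the three numbers; the steps of a 2.3-fold higher number from compound 2 to compound 3 (0.35 log units; beyond the scatter) and a 4.9-fold lower number from compound 1 to compound 3 (0.69 log units; beyond the scatter) place it with the nearer neighbour a modest distance off and the further one clearly apart. All three compounds share one core and differ only in the group on the carbonyl carbon. Compound 4 `Cc1nc(S(C)(=O)=O)ccc1Oc1ncnc(OC2CCN(C(=O)c3ncc(Cl)cn3)CC2)c1F` carries the change (5-chloropyrimidin-2-yl in place of 1,1-difluoropropyl on a carbonyl carbon). Among the measured compounds shown here, the measured steps at this position, a 4.9-fold lower number from compound 1 to compound 3 (0.69 log units; beyond the scatter), a 2.3-fold higher number from compound 2 to compound 3 (0.35 log units; beyond the scatter) and an 11-fold lower number from compound 1 to compound 2 (1.05 log units; beyond the scatter), show that this group moves the number over a wide span, yet none of them brings in an aromatic ring, so no measured step maps onto a 5-chloropyrimidin-2-yl directly. Compound 4 is therefore expected to show a 1.0-fold higher number from compound 3 to compound 4 (0.00 log units; within the scatter), with much uncertainty in either direction. The estimate for compound 4 in this assay is 70 nM, between 15 nM and 350 nM.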

Compound 4, half-maximal effective concentration: 30.9 nM
Beside the measured number, compound 4's estimate is 2.3-fold (0.36 log units) above it, and the stated range covers the measured number.
By their numbers in this assay, from the lowest: compounds 2 and 4 (each within the scatter of the next); then compound 3; then compound 1.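

In this assay, the change shows that this carbonyl carbon accepts an aromatic ring, which none of the earlier groups carried: 5-chloropyrimidin-2-yl in place of 1,1-difluoropropyl gives a modest gain (a 2.2-fold lower number from compound 3 to compound 4 (0.35 log units; beyond the scatter)). Set against the (tert-butyl)sulfanyl group, the ring makes no difference that can be told from scatter (a 1.0-fold higher number from compound 2 to compound 4 (0.00 log units; within the scatter)), so two groups of quite different shape reach the same level, while against (3-(trifluoromethyl)oxetan-3-yl)oxy the step is large (an 11-fold lower number from compound 1 to compound 4 (1.04 log units; beyond the scatter)). Nothing available accounts for any of these differences.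

Going by these compounds, what a plain phenyl ring or a pyrimidin-2-yl without the chlorine would give on this carbonyl carbon stays open. So does the question of whether the ring nitrogens or the chlorine carry the step, and how a dialkylamine in this place would compare.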